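The source may hold more compounds than are shown below. What is called first, only, known or untested is meant among the compounds shown, and "the series" means these compounds.

Working notes on the series, in a functional assay on MCF7 cells (Homo sapiens) for cytotoxicity, read by MTT assay, with a stated time of 48 h; on this read-out lower numbers stand for stronger inhibition and higher numbers for weaker inhibition.

Compound 1 `CCCCCCCCCCCCCCNC(=O)[C@@H](N)[C@@H](C)O` gives 10700 nM in this assay. Compound 2 `CCCCCCCCCCCCCCNC(=O)[C@@H](NS(=O)(=O)c1ccc(C)cc1)[C@@H](C)O` gives 12900 nM in this assay; the change a 1.2-fold higher number from compound 1 to compound 2 (0.08 log units; within the scatter) leaves the two numbers together within the usual scatter, so no ordering between compound 1 and compound 2 is established. Compound 2 therefore stands level with compound 1 on the numbers shown.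

Compound 3 `CCCCCCCCCCCCCCCCCCNC(=O)[C@@H](NS(=O)(=O)c1ccc(C)cc1)[C@@H](C)O` carries the change (butyl in place of hydrogen on a saturated chain carbon, ten or more bonds along the chain from an amide-type nitrogen). Among the compounds with values here, the single measured step concerns the group on the amine nitrogen and not the chain, so no measured step bears directly on this change; nothing in the data indicates a shift of the number in either direction. The expectation is a step of a 1.1-fold lower number from compound 2 to compound 3 (0.03 log units; within the scatter) that stays within the scatter. For compound 3 the estimated value in this assay is 12000 nM, expected between 4000 nM and 40000 nM.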

Compound 3, half-maximal inhibitory concentration: 60100 nM
Compound 3: middle estimate off by 5.0-fold (0.70 log units), on the low side; the measured number lies above the stated range.
By their numbers in this assay, from the lowest: compounds 1 and 2 (each within the scatter of the next); then compound 3.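

Butyl in place of hydrogen on a saturated chain carbon gives a 4.7-fold higher number from compound 2 to compound 3 (0.67 log units; beyond the scatter) in this assay and is the only step in the series beyond the scatter. The chain therefore registers in this read-out, with weaker inhibition going with the added butyl, while a 1.2-fold higher number from compound 1 to compound 2 (0.08 log units; within the scatter) on the amine nitrogen established no ordering. No measurement available here accounts for the size or direction of this step.

The compounds shown leave open whether a shorter chain would lower the number or leave it level, and whether the same butyl change on the free amine of compound 1 would read alike. Also open, from the compounds shown here alone, is how an amine or a carboxylic acid in place of butyl at this chain position would read.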